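Swapping the aryl group on compound 2's exocyclic double bond

This account rests on a few compounds, and the source may have more. Where it says the series, first, only, none or still open, it means among the compounds named here.

Measured so far:
compound 1, `Cc1cc(/C=C2\C(=O)Nc3ccc(C(=O)c4ccco4)cc32)cc(C)c1O`, 9%
compound 2, `O=C1Nc2ccc(C(=O)c3ccco3)cc2/C1=C/c1ccc(Br)c(O)c1`, -5.6%

Among the compounds with values here, compound 2 stands lowest of the two numbers in an assay on HeLa cells for inhibition of Kinesin-like protein KIF15 (Homo sapiens), read by microscopy, with stated times of 2 s and 20 s, tested at 750 nM; on this read-out higher numbers stand for more inhibition at the one concentration tested (going by the name of the read-out) and lower numbers for less inhibition; its nearest neighbour is compound 1, and the single measured step, a number 14.6 percentage points lower from compound 1 to compound 2 (beyond the scatter), is a modest one that lies beyond the scatter. Within the data shown here, that step is the only guide to how the aryl group on the double-bonded chain carbon shapes the read-out, and it shows that changing this group can move the number by a modest amount in either direction.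

Compound 3, `O=C1Nc2ccc(C(=O)c3ccco3)cc2/C1=C/c1ccnc(Cl)c1`, differs from compound 2 as follows:
2-chloropyridin-4-yl in place of 4-bromo-3-hydroxyphenyl on a double-bonded chain carbon bound to a double-bonded ring carbon

Among the measured compounds shown here, no measured step in this assay involves a 2-chloropyridin-4-yl group, so the available data give no direct bearing on the new substituent. Given the modest size of the one known step, compound 3 is expected to sit close to compound 2, with a step of a number 5.6 percentage points higher from compound 2 to compound 3 (within the scatter) that may well fall within the scatter. The estimate for compound 3 in this assay is therefore 0%, within a range from -15% to 15%.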

Compound 3, a percentage reported as inhibition, at one concentration (the size of the read-out at that concentration, not a potency): 15.8%
For compound 3 the middle estimate is 15.8 percentage points below the measured one; measured number outside the range, above it.
By their numbers in this assay, from the lowest: compound 2; then compounds 1 and 3 (each within the scatter of the next).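

In this assay, the aryl group on the double-bonded chain carbon proves able to raise the number as well as lower it: a number 21.4 percentage points higher from compound 2 to compound 3 (beyond the scatter), as 2-chloropyridin-4-yl, with a nitrogen in its ring and no hydrogen-bond donor, replaces 4-bromo-3-hydroxyphenyl. The hydrogen-bond donor of 4-bromo-3-hydroxyphenyl is therefore not needed for the read-out to stand above that of compound 2, and the other comparison, a number 6.8 percentage points higher from compound 1 to compound 3 (within the scatter), places two quite different aryl groups within the scatter of each other, leaving compound 2 as the lowest of the three. No measurement among those shown accounts for these differences.

Since the ring nitrogen, the chlorine, the bromine and the hydroxyl all change in the single step to compound 3, the compounds shown cannot say which of these changes goes with the higher number. On these data alone, it also stays open how an amine or a methoxy group in place of the chlorine on the pyridine ring would read in this assay, and whether any group at this place would lift the number well clear of the scatter.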